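Swapping 3-Bromophenyl for 4-Methoxyphenyl: What Should Change?

The source may report more compounds than this note shows. Statements on the series, on what has been measured and on what is new or still open speak of the compounds shown alone.

Three related compounds have been tested so far in a functional assay (mast cells) for inhibition, with Rattus norvegicus as the target; on this read-out lower numbers stand for an effect already at smaller amounts and higher numbers for an effect only at larger amounts of compound. Compound 1 (`CC1CC/C(=N\Nc2ccccc2)c2ncc(CC(=O)O)c(=O)n21`) gives 430000 nM, compound 2 (`O=C(O)c1cnc2n(c1=O)CCC/C2=N\Nc1ccccc1`) gives 2900 nM, and compound 3 (`CC1CC/C(=N\Nc2cccc(Br)c2)c2ncc(C(=O)O)c(=O)n21`) gives 6700 nM. Compound 3 therefore holds the middle place, with the second highest of the three numbers. It lies modestly above compound 2 and far below compound 1, and both gaps are beyond the usual scatter of repeated measurements.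

Compound 4 (`COc1ccc(N/N=C2\CCC(C)n3c2ncc(C(=O)O)c3=O)cc1`) has not yet been measured. It keeps the rest of compound 3 but carries 4-methoxyphenyl in place of 3-bromophenyl on an amine nitrogen. Going by the values given here, no two measured compounds differ in only one place, so the data hold no direct example of what this swap does. The expectation therefore leans on compound 3 at 6700 nM and on compound 2 at 2900 nM, the two closest values. The expected change is small, with an estimated 1.3-fold lower number from compound 3 to compound 4 (0.13 log units; within the scatter), which would stay within the scatter. Compound 4 is estimated at 5000 nM, with an expected range from 1500 nM to 20000 nM.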

Compound 4, half-maximal effective concentration: 128000 nM
The estimate for compound 4 lay 26-fold (1.41 log units) below the measured number; the whole stated range lies below it.
By their numbers in this assay, from the lowest: compound 2; then compound 3; then compound 4; then compound 1.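

In this assay the group on the amine nitrogen turns out to matter a great deal: replacing 3-bromophenyl with 4-methoxyphenyl gives a 19-fold higher number from compound 3 to compound 4 (1.28 log units; beyond the scatter) with the rest of the molecule unchanged. Going by these compounds alone, this is the first pair of compounds that differ in one place only, and it gives the first direct sign that the read-out is sensitive to what sits on this aromatic ring. The swap alters both the kind of group on the ring and where it stands, and it brings in a hydrogen-bond acceptor that 3-bromophenyl lacks, but nothing available here shows what lies behind the large shift.

The compounds shown leave open whether the change in group or the change in its ring position carries the effect, a question that 4-bromophenyl and 3-methoxyphenyl on the same core would help to separate. As far as these compounds go, it also remains open where an unsubstituted phenyl, or a phenyl ring carrying chlorine or a nitrile, would fall relative to compound 3 and compound 4 with the rest of the structure held constant.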